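A few compounds are considered here, and "the series" means these few. Any claim that something is new, unique, unknown or untested is made for them only; others in the source may bear on it.

Measured compounds in a functional assay with Rattus norvegicus as the target; on this read-out lower numbers stand for an effect already at smaller amounts and higher numbers for an effect only at larger amounts of compound:
- compound 1 `CC1(C)C=C(n2ccccc2=O)c2cc(S(=O)(=O)NCCO)ccc2O1`: 110 nM
- compound 2 `CC1(C)C=C(n2ccccc2=O)c2cc(S(=O)(=O)Nc3ccccc3)ccc2O1`: 3.09 nM; 2 nM (2 entries), with the several entries of compound 2 in this assay, 3.09 nM; 2 nM (2 entries)
- compound 3 `COc1ccc(NS(=O)(=O)c2ccc3c(c2)C(n2ccccc2=O)=CC(C)(C)O3)cc1`: 117 nM

Compound 3 holds the highest of the two single numbers in this assay, but its nearest neighbour, compound 1, sits within the scatter of it; compound 2 stands well apart from both with its several entries. For the measured compounds named here, the only step computed between measured compounds is a 1.1-fold higher number from compound 1 to compound 3 (0.03 log units; within the scatter), which exchanges the whole sulfonamide substituent and still leaves the read-out unchanged.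

Compound 4 `CC1(C)C=C(n2ccccc2=O)c2cc(S(=O)(=O)Nc3ccc(C#N)cc3)ccc2O1` differs from compound 3 in one place: cyano in place of methoxy on an aromatic carbon. Going by the values given here, no measured step touches this position, so the change has no direct precedent here. What the values show is that compound 2, with an unsubstituted phenyl on the sulfonamide nitrogen, reads much lower than compound 3, which carries the 4-methoxyphenyl; whether a cyano at the same place behaves like the methoxy or like no substituent cannot be read from the series. The expectation for compound 4 is therefore a broad one, centred somewhat below compound 3, with the expected step of a 2.0-fold lower number from compound 3 to compound 4 (0.29 log units; within the scatter). Compound 4 is estimated at 60 nM, within 10 nM to 300 nM.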

Compound 4, half-maximal effective concentration: 263 nM
Compound 4: middle estimate off by 4.4-fold (0.64 log units), on the low side; the measured number falls inside the stated range.
By their numbers in this assay, from the lowest: compounds 1 and 3 (each within the scatter of the next); then compound 4.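

In this assay, cyano in place of methoxy on an aromatic carbon, para to a large group, moves the read-out modestly (a 2.2-fold higher number from compound 3 to compound 4 (0.35 log units; beyond the scatter)), so this place is not indifferent to the group it carries. Set against 2-hydroxyethyl on the sulfonamide nitrogen, 4-cyanophenyl also gives a modest rise (a 2.4-fold higher number from compound 1 to compound 4 (0.38 log units; beyond the scatter)), whereas 4-methoxyphenyl stays within the scatter (a 1.1-fold higher number from compound 1 to compound 3 (0.03 log units; within the scatter)). Neither compound 3 nor compound 4 comes near compound 2, which carries no group at this place: the several entries of compound 2 in this assay, 3.09 nM; 2 nM (2 entries).

From the compounds shown here alone, whether any group at this place can keep numbers as low as those of compound 2 remains open; a fluorine, a hydroxyl or an amine there would bear on that. Also open, going by these compounds, is how cyano and methoxy would read on another aromatic carbon of the same phenyl.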